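Adding a second bromo to compound 2

A few compounds are considered here, and "the series" means these few. Any claim that something is new, unique, unknown or untested is made for them only; others in the source may bear on it.

Measured so far:
compound 1 (`CC#CCn1c(N2CCC[C@@H](N)C2)cc(=O)n(Cc2cc(OC)c(OC)c(Br)c2Br)c1=O`) gives 3.21
compound 2 (`COc1cc(Cn2c(=O)cc(N3CCC[C@@H](N)C3)n(Cc3cc(F)ccc3C#N)c2=O)cc(Br)c1OC`) gives 3.49

Both numbers come from a physicochemical assay for lipophilicity (a lower number here means a more polar compound, a higher number a more lipophilic compound), and lie within the usual scatter of each other, so compound 2 (3.49) stands level with compound 1 rather than apart from it. Within the data shown here, with only two measured compounds, the series offers no trend to lean on.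

Compound 3 (`COc1cc(Cn2c(=O)cc(N3CCC[C@@H](N)C3)n(Cc3cc(F)ccc3C#N)c2=O)c(Br)c(Br)c1OC`) differs from compound 2 by bromo in place of hydrogen on an aromatic carbon and so carries 2,3-dibromo-4,5-dimethoxyphenyl where compound 2 carries 3-bromo-4,5-dimethoxyphenyl. The incoming bromo sits on an aromatic carbon, ortho to a bromo group and para to a methoxy group. The rest of the structure stays the same.

Among the measured compounds shown here, no measured pair shows this change on its own, so the expectation rests on the structural change alone. In this assay an upward step beyond the scatter is expected, estimated as a number 0.51 log units higher from compound 2 to compound 3 (beyond the scatter) in size. For compound 3 the estimated value is 4 (expected range 3.6 to 4.4).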

Compound 3, partition coefficient: 4.32
The estimate for compound 3 lay 0.32 log units below the measured number; low and high end bracket the measured number.
By their numbers in this assay, from the lowest: compounds 1 and 2 (each within the scatter of the next); then compound 3.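

In this assay, the 2,3-dibromo-4,5-dimethoxyphenyl group stands clearly apart from the 3-bromo-4,5-dimethoxyphenyl group, with a number 0.83 log units higher from compound 2 to compound 3 (beyond the scatter), so a bromo on this aromatic carbon, ortho to a bromo group and para to a methoxy group, shifts the read-out even when one bromo is already in place. With the 2,3-dibromo-4,5-dimethoxyphenyl group held constant, the other end of the structure also counts: 2-cyano-5-fluorophenyl in place of prop-1-yn-1-yl on the saturated chain carbon bound to an aromatic nitrogen gives a number 1.11 log units higher from compound 1 to compound 3 (beyond the scatter). Compound 1 and compound 2 differ in two places, and their level numbers gave no sight of these two separate steps, each beyond the scatter, which run in opposite directions on the way between those two compounds.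

Still open, going by these compounds, is how a chloro, a methyl or a carboxylic acid on the same aromatic carbon would compare with bromo. The compounds shown offer no measurement that accounts for either step.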